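The source may hold more compounds than are shown below. What is called first, only, known or untested is meant among the compounds shown, and "the series" means these compounds.

Measured in a functional assay on K562 cells (Homo sapiens) for antiproliferative activity, read by CellTiter-Glo and CCK-8 assay, with a stated time of 72 h; a higher number here means a weaker inhibitor of growth, a lower number a stronger inhibitor of growth:
Compound 1, `CNc1nc(Nc2ccc(C)c([N+](=O)[O-])c2)ncc1C(=O)Nc1cc(NC(=O)c2cccc(C(F)(F)F)c2)ccc1C`, gives 52 nM.
Compound 2, `CNc1nc(Nc2ccc(C)c([N+](=O)[O-])c2)ncc1C(=O)Nc1cc(NC(=O)c2ccccc2OC)ccc1C`, reaches only the limit > 10000 nM.
Compound 3, `CNc1nc(Nc2ccc(C)c([N+](=O)[O-])c2)ncc1C(=O)Nc1cc(NC(=O)c2ccc(OC)c(OC)c2)ccc1C`, gives 680 nM.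

Of the two numbers, compound 3 holds the higher one; its nearest neighbour is reached by a 13-fold higher number from compound 1 to compound 3 (1.12 log units; beyond the scatter). Compound 4, `CNc1nc(Nc2ccc(C)c(N)c2)ncc1C(=O)Nc1cc(NC(=O)c2ccc(OC)c(OC)c2)ccc1C`, differs from compound 3 by amino in place of nitro on an aromatic carbon. The measured steps, an at least 190-fold higher number from compound 1 to compound 2 (2.28 log units; beyond the scatter), a 13-fold higher number from compound 1 to compound 3 (1.12 log units; beyond the scatter) and an at least 14-fold lower number from compound 2 to compound 3 (1.16 log units; beyond the scatter), each exchange the aryl on the carbonyl carbon and leave the nitro in place, so none of them bears on this change, and its size cannot be read from them. A moderate rise in the number is expected, a 2.2-fold higher number from compound 3 to compound 4 (0.34 log units; beyond the scatter). Compound 4 is therefore estimated at 1500 nM in this assay, within a range from 300 nM to 8000 nM.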

Compound 4, concentration for 50% growth inhibition: 380 nM
Beside the measured number, compound 4's estimate is 3.9-fold (0.60 log units) above it; low and high end bracket the measured number.
By their numbers in this assay, from the lowest: compound 1; then compounds 4 and 3 (each within the scatter of the next). At a limit, above all of these: compound 2.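

In this assay, amino in place of nitro on the aromatic carbon ortho to a methyl group gives a 1.8-fold lower number from compound 3 to compound 4 (0.25 log units; within the scatter). The earlier compounds shown here all kept the nitro and showed large steps only with the aryl on the carbonyl, whereas this position, with the 3,4-dimethoxyphenyl in place, holds either group without a change beyond the scatter. Nothing measured here accounts for this result. Still open, from the compounds shown here alone, is whether amino and nitro also stay within the scatter of each other with the 3-(trifluoromethyl)phenyl of compound 1. Going by these compounds, how a nitrile or a methoxy would read at this carbon also remains open.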